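This account rests on a few compounds, and the source may have more. Where it says the series, first, only, none or still open, it means among the compounds named here.

Compound 1 `CNC(=O)c1cc(C(=O)Nc2cnn(C)c2)cc2c1OC[C@H]2c1ccccc1`: in a physicochemical assay for solubility (a lower number here means a less soluble compound, a higher number a more soluble compound), compound 1 gives >= 189 ug/mL, which is a limit of the assay rather than a number.
Compound 2 `CNC(=O)c1cc(C(=O)N[C@H]2[C@@H]3COC[C@@H]32)cc2c1OC[C@@]2(CO)c1ccccc1`: in this assay compound 2 gives >= 202 ug/mL, also a limit.
Compound 3 `CNC(=O)c1cc(C(=O)N[C@H]2[C@@H]3COC[C@@H]32)cc2c1OC[C@H]2c1cccc2[nH]ccc12`: in this assay compound 3 gives >= 171 ug/mL, again a limit.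

Compound 1 therefore stands only at a limit in this assay, as do the two other compounds the limit of >= 171 ug/mL in this assay, at which 1 of the 3 values shown sits (the limit of >= 202 ug/mL in this assay, at which 1 of the 3 values shown sits), and no order among the three can be read from such figures. Compound 4 `CNC(=O)c1cc(C(=O)NC2CC2)cc2c1OC[C@H]2c1ccccc1` differs from compound 1 in one place: cyclopropyl in place of 1-methyl-1H-pyrazol-4-yl on an amide-type nitrogen. Among the measured compounds shown here, no measured pair shares this change, so its effect in this assay is untested. A downward step an at least 1.5-fold lower number from compound 1 to compound 4 (0.19 log units; that floor lies within the scatter) is nonetheless expected, somewhat beyond the usual scatter. Compound 4 is accordingly estimated at 120 ug/mL, in the range 40 ug/mL to 300 ug/mL.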

Compound 4, solubility: >= 190 ug/mL
Compound 4 was reported as a limit (the forecaster's own chance of this, stated with the estimate: 35%); middle value at least 1.5-fold (0.19 log units) from the limit.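

Compound 1 and compound 4 both stand only at a limit in this assay, and the step between them cannot be read. The compounds shown leave open whether cyclopropyl in place of 1-methyl-1H-pyrazol-4-yl changes the read-out at all.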